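Shifting a methyl on the dimethylphenyl of compound 2

The source may hold more compounds than are shown below. What is called first, only, known or untested is meant among the compounds shown, and "the series" means these compounds.

Compound 2 `Cc1ccc(C)c(-n2nncc2CN2C(=O)C3(C(C#N)=C(N)Oc4c(N)cc5nc6ccccc6nc5c43)c3ccccc32)c1` carries a 2,5-dimethylphenyl on an aromatic nitrogen of the shared core. In an ADME assay on HUVEC cells (Homo sapiens) for antiproliferative activity, read by MTT assay, with a stated time of 48 h (on this read-out higher numbers stand for weaker inhibition and lower numbers for stronger inhibition), compound 2 reaches only a limit of the assay, > 50000 nM. Among the measured compounds shown here, its one measured neighbour, compound 1 `Cc1cccc(-n2nncc2CN2C(=O)C3(C(C#N)=C(N)Oc4c(N)cc5nc6ccccc6nc5c43)c3ccccc32)c1`, differs from it by methyl in place of hydrogen on an aromatic carbon. In this assay compound 1 likewise gives only a limit, > 50000 nM. The step that the two limits leave unreadable from compound 1 to compound 2 therefore cannot be sized, as the limit of > 50000 nM in this assay, at which 2 of the 2 values shown sit, shows. Compound 3 `Cc1cc(C)cc(-n2nncc2CN2C(=O)C3(C(C#N)=C(N)Oc4c(N)cc5nc6ccccc6nc5c43)c3ccccc32)c1` has the same atoms joined differently: 3,5-dimethylphenyl in place of 2,5-dimethylphenyl on an aromatic nitrogen. For the measured compounds named here, no measured step bears directly on this rearrangement, and the only comparison available, between compound 1 and compound 2, ends at the limit on both sides. The step of a number no higher from compound 2 to compound 3 (the limit leaves the size open) is therefore expected to be none beyond the scatter. For compound 3 the estimate in this assay is 50000 nM, within 20000 nM to 200000 nM, most likely again reported as a limit.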

Compound 3, half-maximal inhibitory concentration: > 50000 nM
Compound 3: a limit, no number; the forecaster's own chance of this, stated with the estimate: 85%; the middle value sits exactly at the limit.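

Among the compounds shown here, compound 3, like compound 1 and compound 2, gives only a limit in this assay and so no step among the three can be read: the limit of > 50000 nM in this assay, at which 3 of the 3 values shown sit. The compounds shown leave open how strongly any of the three inhibits, and whether moving or adding a methyl changes that.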